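Swapping Cyano for Nitro on a Weak Compound

A few compounds are considered here, and "the series" means these few. Any claim that something is new, unique, unknown or untested is made for them only; others in the source may bear on it.

Among the measured compounds shown here, compound 1 `CC1(C)C(=O)N(c2ccc(C#N)cc2C(F)(F)F)C(=S)N1c1ccc(S(F)(F)(F)(F)F)cc1` and compound 2 `CC1(C)C(=O)N(c2ccc(C#N)cc2C(F)(F)F)C(=S)N1c1cccc(S(F)(F)(F)(F)F)c1` are the only two compounds measured so far. Both were tested in a functional assay on CWR22R cells (Homo sapiens) for antiproliferative activity, read by propidium iodide staining, with a stated time of 96 h (a lower number here means a stronger inhibitor, a higher number a weaker inhibitor), a test of how well a compound holds back the growth of these cells. In this test compound 1 gives 5400 nM and compound 2 gives 100000 nM. Compound 2 therefore has the higher of the two numbers and is the weaker inhibitor, by a gap well beyond the scatter.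

Compound 3 `CC1(C)C(=O)N(c2ccc([N+](=O)[O-])cc2C(F)(F)F)C(=S)N1c1cccc(S(F)(F)(F)(F)F)c1` keeps the rest of compound 2 and changes one group: nitro in place of cyano on an aromatic carbon. Put simply, this is nitro in place of cyano on an aromatic carbon, meta to a trifluoromethyl group and para to a large group. For the measured compounds named here, no measured pair shows this swap, so the data give no direct guide to its effect. Going by the values given here, compound 2, at 100000 nM, holds the higher of only two numbers, so a small move downward in this assay seems a little likelier than a rise, though within the scatter. The expected change is a 1.7-fold lower number from compound 2 to compound 3 (0.22 log units; within the scatter). The estimate for compound 3 is 60000 nM, with an expected range from 15000 nM to 150000 nM.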

Compound 3, half-maximal inhibitory concentration: 43900 nM
The estimate for compound 3 lay 1.4-fold (0.14 log units) above the measured number; the measured number falls inside the stated range.
By their numbers in this assay, from the lowest: compound 1; then compound 3; then compound 2.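

In this assay, putting nitro in place of cyano on this aromatic carbon, meta to a trifluoromethyl group and para to a large group, gives a 2.3-fold lower number from compound 2 to compound 3 (0.36 log units; beyond the scatter), a modest step. Among the compounds shown here, this is the first direct sign that the number in this test responds to a change at this position, though a single swap shows only that the position is not indifferent, not how far the number can move. The gain is also limited in absolute terms, since compound 3 still gives 43900 nM and remains a weak inhibitor, and nothing at hand explains why nitro does slightly better than cyano here.

Whether the same swap would give a step of similar size on compound 1, the compound with the lower number of the original pair, remains an open question. It is also unknown how an amine, a carboxylic acid or a simple methyl group on this same aromatic carbon would compare with cyano and nitro, so the two groups seen so far give only a narrow view of this position.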